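Sulfonamide series on the shared core: arylsulfonyl variants

This account rests on a few compounds, and the source may have more. Where it says the series, first, only, none or still open, it means among the compounds named here.

Measured compounds in a functional assay on KYSE-510 cells (Homo sapiens) for antiproliferative activity, read by crystal violet staining, with a stated time of 96 h; on this read-out higher numbers stand for weaker inhibition of growth and lower numbers for stronger inhibition of growth:
compound 1 `COc1cc(C)ccc1S(=O)(=O)NC1=NCCN1C(=S)SN1CCn2c1nsc2=S` gives >= 20000 nM
compound 2 `O=S(=O)(NC1=NCCN1C(=S)SN1CCn2c1nsc2=S)c1ccccc1Cl` gives >= 20000 nM
compound 3 `O=S(=O)(NC1=NCCN1C(=S)SN1CCn2c1nsc2=S)c1cccc(Cl)c1` gives >= 20000 nM
Each of these three values is a limit of the assay, not a number.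

Compound 3 therefore stands at the limit, alongside the other two; (the limit of >= 20000 nM in this assay, at which 3 of the 3 values shown sit). The steps a step that the two limits leave unreadable from compound 1 to compound 2, a step that the two limits leave unreadable from compound 1 to compound 3 and a step that the two limits leave unreadable from compound 2 to compound 3 cannot be sized, so no trend across the arylsulfonyl groups can be read.

Compound 4 `O=S(=O)(NC1=NCCN1C(=S)SN1CCn2c1nsc2=S)c1ccc2ccccc2c1` differs from compound 3 by naphthalen-2-yl in place of 3-chlorophenyl on a sulfonyl sulfur. For the measured compounds named here, none of the measured steps is readable, so the expectation rests only on all three values sitting at the limit. Compound 4 is therefore expected to give 20000 nM, with a range from 8000 nM to 50000 nM, most likely again reported only as a limit. The expected step of a number no higher from compound 3 to compound 4 (the limit leaves the size open) is thus estimated as none beyond the scatter.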

Compound 4, concentration for 50% growth inhibition: >= 20000 nM
Compound 4: a limit, no number; the forecaster's own chance of this, stated with the estimate: 75%; the middle value lies on the limit itself.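

In this assay, no step from compound 1, compound 2 or compound 3 to compound 4 can be read, because all four values are limits, not numbers: the limit of >= 20000 nM in this assay, at which 4 of the 4 values shown sit.

The compounds shown leave open whether the arylsulfonyl groups on the shared core differ at all in growth inhibition.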